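The compounds below may be only part of what the source reports. "The series", "measured", "known", "first", "only" and "open" are said of these compounds alone.

Measured compounds:
- compound 1 `COc1ccccc1-n1nc(C2CC(C)(C)OC(C)(C)C2)cc1-c1ccc(Cl)cc1`: 97%
- compound 2 `COCCCc1cc(-c2ccc(Cl)cc2)n(-c2ccccc2OC)n1`: 58%
- compound 3 `COc1ccccc1-n1nc(C2C[C@H](C)O[C@@H](C)C2)cc1-c1ccc(Cl)cc1`: 40%

In an ADME assay on microsomes from liver (Homo sapiens) for metabolic stability, with a stated time of 10 min (a higher number here means that more of the compound is left, a lower number that less of the compound is left), compound 2 gives 58%, the second highest of the three numbers; compound 3 sits nearest, a number 18 percentage points lower from compound 2 to compound 3 (beyond the scatter), while compound 1 is furthest, a number 39 percentage points lower from compound 1 to compound 2 (beyond the scatter).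

Compound 4 `COc1ccccc1-n1nc([C@@H]2CCO[C@@H](C(C)C)C2)cc1-c1ccc(Cl)cc1` is not yet measured. It differs from compound 2 in one place: 2-isopropyloxan-4-yl in place of 3-methoxypropyl on an aromatic carbon.

Among the compounds with values here, two measured steps bear on this. Replacing the same 3-methoxypropyl chain by a substituted oxan-4-yl ring gave opposite results: a number 39 percentage points lower from compound 1 to compound 2 (beyond the scatter) in this assay, so the tetramethyl ring stands far above the chain, whereas a number 18 percentage points lower from compound 2 to compound 3 (beyond the scatter), so the dimethyl ring stands below it. The 2-isopropyloxan-4-yl ring of compound 4 is a third pattern of substitution on the same ring, and the two precedents do not agree on direction. The expected step is therefore uncertain and no change beyond the scatter is assumed, with a wide range covering both outcomes.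

Compound 4 is estimated at 55% in this assay (range 30% to 80%), which is expected to mean a number 3 percentage points lower from compound 2 to compound 4 (within the scatter).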

Compound 4, percent of the compound remaining: 26%
Estimate against measurement, compound 4: 29 percentage points above; the whole stated range lies above it.
By their numbers in this assay, from the lowest: compound 4; then compound 3; then compound 2; then compound 1.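

With a number 32 percentage points lower from compound 2 to compound 4 (beyond the scatter) in this assay, a second substituted oxan-4-yl ring stands below the 3-methoxypropyl chain, leaving compound 1 as the only ring compound shown above that chain. The substitution pattern on the ring therefore matters greatly at this position, with a number 71 percentage points lower from compound 1 to compound 4 (beyond the scatter) despite the shared oxan-4-yl ring, and a smaller separation of the two less substituted rings, with a number 14 percentage points lower from compound 3 to compound 4 (beyond the scatter). No measurement shown gives a reason for these differences.

Within the data shown here, it remains open whether the high value of compound 1 needs all four methyl groups or only the pair on one side of the ring oxygen, and what the defined stereocentres contribute on their own. Also open, from the compounds shown here alone, is how a 2,2-dimethyloxan-4-yl ring or a piperidin-4-yl ring, an amine in place of the ring oxygen, would compare at this position.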